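Swapping a Para Substituent on a Histamine Agonist

This account rests on a few compounds, and the source may have more. Where it says the series, first, only, none or still open, it means among the compounds named here.

Measured so far:
- compound 1, `Cc1ccc(C(CC/N=C(\N)NCCCc2c[nH]cn2)c2ccccn2)cc1`: 7.15
- compound 2, `N=C(NCCCc1c[nH]cn1)NCCC(c1ccc(Cl)cc1)c1ccccn1`: 7.39

Two compounds share a long chain ending in an imidazole ring and differ only in the group on the phenyl ring. In a functional assay on muscle tissue for agonist activity at histamine H2 receptor (Cavia porcellus) (a lower number here means a less potent compound, a higher number a more potent compound, by a factor of ten per unit of this negative logarithm), compound 1 gives 7.15. In this assay compound 2 gives 7.39. Compound 2 has the higher of the two numbers, but the gap to compound 1 lies within the scatter of repeated measurements, so the two values cannot be told apart with confidence.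

The next compound, compound 3, `N=C(NCCCc1c[nH]cn1)NCCC(c1ccc(C(F)(F)F)cc1)c1ccccn1`, keeps the whole skeleton of compound 2 and changes one point: trifluoromethyl in place of chloro on an aromatic carbon. Within the data shown here, no measured pair in this set shows what such an exchange does, so the expectation must rest on the closeness of compound 1 and compound 2, where a different group at the same place made no difference beyond the scatter.

On that basis, compound 3 is expected to stay near compound 2, with a step of a number 0.09 log units lower from compound 2 to compound 3 (within the scatter) in this assay that is not expected to exceed the scatter. The estimate for compound 3 in this assay is 7.3, within a range from 6.7 to 7.9.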

Compound 3, negative logarithm of the half-maximal effective concentration: 7.23
Compound 3: middle estimate off by 0.07 log units, on the high side; low and high end bracket the measured number.
By their numbers in this assay, from the lowest: compounds 1, 3 and 2 (each within the scatter of the next).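

Trifluoromethyl carries more heavy atoms than chloro, yet in this assay putting it on the same aromatic carbon gives a number 0.16 log units lower from compound 2 to compound 3 (within the scatter), so this larger exchange, too, produces no step that can be told apart from repeated-measurement noise. With compound 3 there are now three different groups at this place, and compounds 1, 2 and 3 all lie within the scatter of one another, so within this small set the choice among these groups leaves the number effectively unchanged. The data shown give no measured property of these groups that could account for this, so the closeness of the three values is an observation and not an explanation.

As far as these compounds go, what remains open is how far this tolerance extends, since all three groups are uncharged and none counts a hydrogen-bond donor or acceptor at this place under the computed comparison of compounds 2 and 3. An amine, a carboxylic acid or a longer chain on the same aromatic carbon could either keep the number within the scatter or move it well beyond, and the compounds shown cannot say which.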